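Swapping the Amide Cap on a Substance-P Ligand

This account rests on a few compounds, and the source may have more. Where it says the series, first, only, none or still open, it means among the compounds named here.

Two close relatives built on one shared core have been measured in an assay on CHO cells for displacement of a labelled ligand from Substance-P receptor (Homo sapiens) (a lower number here means a stronger inhibitor, a higher number a weaker inhibitor), so far. Compound 1 `Cc1cnc(C(=O)N2C[C@@H](O[C@H](C)c3cc(C(F)(F)F)cc(C(F)(F)F)c3)[C@H](c3ccc(F)cc3)C2)cn1` gives 0.12 nM there, and compound 2 `C[C@@H](O[C@@H]1CN(C(=O)[C@@H]2COC(=O)N2)C[C@H]1c1ccc(F)cc1)c1cc(C(F)(F)F)cc(C(F)(F)F)c1` gives 0.34 nM in the same test. Among the measured compounds shown here, the single step between them, a 2.8-fold higher number from compound 1 to compound 2 (0.45 log units; beyond the scatter) in this assay, shows that exchanging the group on the carbonyl carbon costs a little binding. Of the two numbers, compound 2 stands highest, its nearest neighbour being compound 1 with the lower number.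

Compound 3 `C[C@@H](O[C@@H]1CN(C2=CC(=O)N(C)C2)C[C@H]1c1ccc(F)cc1)c1cc(C(F)(F)F)cc(C(F)(F)F)c1` is not yet measured. It differs from compound 2 in one place: a group of 7 heavy atoms (5 carbon, 1 nitrogen, 1 oxygen; one five-membered non-aromatic ring with 1 hetero atom) in place of a group of 8 heavy atoms (4 carbon, 1 nitrogen, 3 oxygen; one five-membered non-aromatic ring with 2 hetero atoms), on an amine nitrogen in a ring here. The group that leaves carries the carbonyl through which both measured compounds are joined to the ring nitrogen, while the group that enters has no common name.

For the measured compounds named here, only the step from compound 1 to compound 2 bears on this change, and only loosely, since both of those compounds keep a carbonyl on the ring nitrogen. That step was modest, so a modest step in this assay is expected here as well, probably toward a higher number, as a 2.9-fold higher number from compound 2 to compound 3 (0.47 log units; beyond the scatter) would give. Compound 3 is therefore estimated at 1 nM with a likely range from 0.3 nM to 4 nM in this assay.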

Compound 3, half-maximal inhibitory concentration: 0.12 nM
Beside the measured number, compound 3's estimate is 8.3-fold (0.92 log units) above it, outside the stated range (below it).
By their numbers in this assay, from the lowest: compounds 1 and 3 (each within the scatter of the next); then compound 2.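

In this assay, a group joined to the ring nitrogen without the linking carbonyl of compounds 1 and 2 still binds well: replacing (2-oxo-1,3-oxazolidin-4-yl)carbonyl gives a 2.8-fold lower number from compound 2 to compound 3 (0.45 log units; beyond the scatter). This single pair therefore shows that neither that linking carbonyl nor the hydrogen-bond donor of the leaving group is required for a sub-nanomolar number on this core, and the defined stereocentre of the leaving group is not required either. The comparison with the 5-methylpyrazin-2-yl carbonyl group gives no change at the digits printed from compound 1 to compound 3 (within the scatter), so a non-aromatic five-membered ring serves here as well as that six-membered aromatic ring, although no data shown explain why the numbers fall as they do.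

The compounds shown leave open which feature of the entering group matters, such as its ring carbonyl or its methyl group, and a version lacking either one would be needed to separate them. They also leave open how far this position tolerates other kinds of group, such as a plain acetyl group, a small open-chain amine or a carboxylic acid.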